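The compounds below may be only part of what the source reports. "The series", "measured", "known", "first", "only" and "open" are said of these compounds alone.

Measured so far in a physicochemical assay for metabolic stability, read by HPLC, in phosphate buffer, at pH 7.4; a higher number here means that the compound lasts longer, a lower number that the compound disappears faster:
- compound 1 `CN(/N=N/c1ccc(C(N)=O)cc1)C(=O)CCc1ccc(O)cc1`: 118 h
- compound 2 `COC(=O)c1ccc(/N=N/N(C)C(=O)CCc2ccc(O)cc2)cc1`: 102 h

Compound 2, at 102 h, cannot be separated from compound 1 on these numbers, as the two values lie within the scatter of each other.

The next structure is compound 3 `CC(=O)c1ccc(/N=N/N(C)C(=O)CCc2ccc(O)cc2)cc1`, not yet measured in this assay. It carries methyl in place of methoxy on a carbonyl carbon, so that methoxycarbonyl becomes acetyl (methyl in place of methoxy on a carbonyl carbon). The rest of the structure is that of compound 2.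

For the measured compounds named here, one measured step bears on this change, as it falls on the same carbonyl carbon: methoxy in place of amino gave a 1.2-fold lower number from compound 1 to compound 2 (0.06 log units; within the scatter). Going by the values given here, this is thin evidence, since no compound with methyl on this carbon has been measured. With that single step inside the scatter, no step beyond the scatter is expected, and no direction can be assigned. The expected step is a 1.0-fold lower number from compound 2 to compound 3 (0.01 log units; within the scatter).

For compound 3 the estimated half-life is 100 h, with an expected range of 55 h to 180 h.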

Compound 3, half-life: 123 h
Beside the measured number, compound 3's estimate is 1.2-fold (0.09 log units) below it; measured number inside the range.
By their numbers in this assay, from the lowest: compounds 2, 1 and 3 (each within the scatter of the next).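

In this assay methyl in place of methoxy on the carbonyl carbon gives a 1.2-fold higher number from compound 2 to compound 3 (0.08 log units; within the scatter), and methyl in place of amino on that carbon gives a 1.0-fold higher number from compound 1 to compound 3 (0.02 log units; within the scatter). The carbonyl carbon now carries amino in compound 1, methoxy in compound 2 and methyl in compound 3 without a separation among the three, so among these compounds an oxygen or nitrogen attached to that carbon is not needed for a half-life of this size, and acetyl serves as well as methoxycarbonyl. No measurement at hand gives a reason why the three stay together.

Still open, on these data alone, is whether this tolerance holds for hydroxy on the same carbon, which would give a carboxylic acid, for a longer chain such as propyl in place of methyl, or for a nitrile in place of the whole acetyl group. Also open is how much of the half-life rests on the shared core, since all three compounds carry it unchanged and the only variation shown lies on this one carbonyl carbon.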